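The source may report more compounds than this note shows. Statements on the series, on what has been measured and on what is new or still open speak of the compounds shown alone.

Compound 1, `O=C(NO)c1ccc(CNc2nccc(-c3cccnc3)n2)cc1`, carries a hydroxy group on its amide-type nitrogen, and in an assay for inhibition of histone deacetylase 8 (Homo sapiens), read by fluorescence, with stated times of 15 min and 60 min (a lower number here means a stronger inhibitor, a higher number a weaker inhibitor), compound 1 gives 410 nM. Compound 2, `COc1ccc(NC(=O)c2ccc(CNc3nccc(-c4cccnc4)n3)cc2)c(N)c1`, differs only in that place. In this assay compound 2 gives > 20000 nM, which is a limit of the assay and not a number. The measured step of an at least 48-fold higher number from compound 1 to compound 2 (1.68 log units; beyond the scatter) ends at the limit of > 20000 nM in this assay, at which 1 of the 2 values shown sits. Compound 2 thus stands at the weak end of what this assay reports, with no number of its own. Compound 3, `Nc1cc2ccccc2cc1NC(=O)c1ccc(CNc2nccc(-c3cccnc3)n2)cc1`, is reached from compound 2 by a group of 11 heavy atoms (10 carbon, 1 nitrogen; 2 six-membered aromatic rings of carbon only) in place of a group of 9 heavy atoms (7 carbon, 1 nitrogen, 1 oxygen; one six-membered aromatic ring of carbon only), on an amide-type nitrogen. Going by the values given here, the only measured step that bears on this position is an at least 48-fold higher number from compound 1 to compound 2 (1.68 log units; beyond the scatter), which was large and went toward a weaker inhibitor once the hydroxy group was replaced by an aromatic group on the amide-type nitrogen, and compound 3 keeps an aromatic group in that place. The step to compound 3 is therefore expected to be small or none beyond the scatter, a number no higher from compound 2 to compound 3 (the limit leaves the size open), with a fair chance that this assay again reports only a limit. Compound 3 is estimated at 20000 nM, within a range from 5000 nM to 80000 nM.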

Compound 3, half-maximal inhibitory concentration: > 20000 nM
Compound 3 ended at the assay's limit; the forecaster's own chance of this, stated with the estimate: 60%; the middle value sits exactly at the limit.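

Compound 3 shows that the large loss seen with compound 2 is not confined to the 2-amino-4-methoxyphenyl group: with a different group on the amide-type nitrogen, one of 11 heavy atoms with 2 six-membered aromatic rings of carbon only, the comparison with the hydroxy compound in this assay again gives an at least 48-fold higher number from compound 1 to compound 3 (1.68 log units; beyond the scatter). In this assay compound 3 gives > 20000 nM, which is a limit of the assay and not a number. The step between compound 2 and compound 3 cannot be read, so the two aromatic groups cannot be ranked against each other, and the second of them joins the first at the same end of the scale: the limit of > 20000 nM in this assay, at which 2 of the 3 values shown sit.

Among the compounds shown, only the hydroxy group on the amide-type nitrogen gives a number, so it remains open whether anything else in that place, such as an amine, a methoxy group or a plain methyl group, would give one too. As far as these compounds go, how far compound 2 and compound 3 actually lie beyond the limit, and whether they differ from each other at all, also stays open.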